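One Methyl Group Added to a Fully Active Compound

This account rests on a few compounds, and the source may have more. Where it says the series, first, only, none or still open, it means among the compounds named here.

Measured so far:
compound 1 `CCC(C(=O)N1CCN(c2ccccc2F)CC1)N1C(=O)CCC1=O`: 100%
compound 2 `CC(C(=O)N1CCN(c2ccccc2C(F)(F)F)CC1)N1C(=O)CCC1=O`: 100%

Both compounds were tested in a functional assay on the whole organism (strain Swiss) with Mus musculus as the target, in the maximal electroshock model, with a stated time of 0.5 h, at a dose of 300 mg/kg by the intraperitoneal route; on this read-out lower numbers stand for a weaker effect and higher numbers for a stronger effect at the one dose given. In this assay compound 1 gives 100%, and compound 2 gives 100%. Compound 2 thus stands level with compound 1 at the digits shown; the two values differ by nothing beyond the usual scatter, and both sit at the top of the scale. Among the compounds with values here, no single-change step between measured compounds is available, so the pair only shows that the two readings match.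

Compound 3 `CCC(C(=O)N1CCN(c2ccccc2C(F)(F)F)CC1)N1C(=O)CCC1=O` differs from compound 2 by one change: methyl in place of hydrogen on a saturated chain carbon, two bonds along the chain from an amide-type nitrogen in a ring and a carbonyl carbon. Within the data shown here, since no measured pair carries this same change, there is no measured step to lean on; the expectation rests on compound 2, whose reading of 100% already fills the scale. The expected step is no change at the digits printed from compound 2 to compound 3 (within the scatter), none beyond the scatter. Compound 3 is expected to give 100% in this assay, with a likely range from 90% to 100%.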

Compound 3, a percentage reported as activity, at one dose (the size of the read-out at that dose, not a potency): 25%
Compound 3: middle estimate off by 75 percentage points, on the high side, and the stated range ends above it.
By their numbers in this assay, from the lowest: compound 3; then compounds 1 and 2 (each within the scatter of the next).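

In this assay, methyl in place of hydrogen on a saturated chain carbon, two bonds along the chain from an amide-type nitrogen in a ring and a carbonyl carbon, gives a number 75 percentage points lower from compound 2 to compound 3 (beyond the scatter), so this position is not indifferent to one added carbon, something two readings at the top of the scale could not reveal. Trifluoromethyl in place of fluoro on an aromatic carbon gives a number 75 percentage points lower from compound 1 to compound 3 (beyond the scatter), so with the chain of compound 3 held fixed, the aromatic group matters as well, and each change's effect depends on what is present at the other place: compound 3 alone combines this chain with trifluoromethyl, and each single-change neighbour keeps the full reading. Nothing available here accounts for the drop.

Still open, from the compounds shown here alone, is whether a propyl chain at this carbon would lower the reading further, and whether chloro or methoxy on the aromatic carbon would follow fluoro or trifluoromethyl alongside the chain of compound 3. A single dose also cannot show how much margin compound 1 and compound 2 hold beneath their full readings.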